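Chloro in Place of Phenyl on the Shared Core

The source may hold more compounds than are shown below. What is called first, only, known or untested is meant among the compounds shown, and "the series" means these compounds.

Compound 1 `FC(F)(F)c1nc2c(-c3ccccc3)cccc2c(-c2ccccc2)c1-c1ccccc1`: > 300000 nM
Compound 2 `N#Cc1cccc(-c2cccc3c(Cl)c(Br)c(C(F)(F)F)nc23)c1`: > 300000 nM

Of the compounds shown here, two have been tested in an assay for inhibition of ectonucleoside triphosphate diphosphohydrolase 2 (Homo sapiens), read by malachite green, with a stated time of 10 min; a lower number here means a stronger inhibitor, a higher number a weaker inhibitor. For compound 1 the value given, > 300000 nM, is a limit of the assay rather than a number. For compound 2 the value > 300000 nM is likewise a limit. Among the measured compounds shown here, compound 1 therefore stands at the limit, as does the only other value shown (the limit of > 300000 nM in this assay, at which 2 of the 2 values shown sit).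

Compound 3 `FC(F)(F)c1nc2c(-c3ccccc3)cccc2c(Cl)c1-c1ccccc1` differs from compound 1 in one place: chloro in place of phenyl on an aromatic carbon. Compound 2 also carries a chloro on its core, though it differs from compound 3 elsewhere, so only the two values themselves can be set side by side. For the measured compounds named here, no step between measured compounds is available. The step expected in this assay is a number no higher from compound 1 to compound 3 (the limit leaves the size open), none beyond the scatter. Compound 3 is estimated at 300000 nM, with a range from 100000 nM to 1000000 nM, and most likely again reported only as a limit.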

Compound 3, half-maximal inhibitory concentration: > 300000 nM
Compound 3 gave a limit, no number; the forecaster's own chance of this, stated with the estimate: 80%; the middle value sits exactly at the limit.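

Compound 1 and compound 3 both stand at a limit of the assay and not at a number, so no step can be read between them: the limit of > 300000 nM in this assay, at which 3 of the 3 values shown sit. The compounds shown leave open whether chloro or phenyl on that aromatic carbon makes any difference in this assay.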